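Branching the ketone chain in a glutamate receptor modulator series

The compounds below may be only part of what the source reports. "The series", "measured", "known", "first", "only" and "open" are said of these compounds alone.

Three compounds with a shared core were measured in an assay on HEK293 cells for positive allosteric modulation of metabotropic glutamate receptor 2 (Rattus norvegicus), read by thallium flux, with a stated time of 2.5 min; on this read-out higher numbers stand for larger maximal responses and lower numbers for smaller maximal responses. Compound 1 `CCCC(=O)c1ccc(OCCCCOc2ccc(C(=O)O)cc2C)c(C)c1O` gives 79.3%. Compound 2 `CC(=O)c1ccc(OCCCCOc2ccc(C(=O)O)cc2C)c(C)c1O` gives 83.1%, a number that sits between the other two, each of them within the scatter of it. Compound 3 `Cc1c(OCCCCOc2ccc(C(=O)O)cc2F)ccc(C(=O)CC(C)C)c1O` gives 85%. Compound 4 `Cc1cc(C(=O)O)ccc1OCCCCOc1ccc(C(=O)C(C)C)c(O)c1C` differs from compound 2 by isopropyl in place of methyl on a carbonyl carbon. Within the data shown here, the only single-place step among the measured compounds also altered the chain on the carbonyl carbon: a number 3.8 percentage points higher from compound 1 to compound 2 (within the scatter), within the scatter, so no step beyond the scatter is expected here, and compound 3, carrying its own chain on the carbonyl carbon, gives a number close to compound 2 as well. Compound 4 is therefore expected to give 83%, between 72% and 93%. The expected step is a number 0.1 percentage points lower from compound 2 to compound 4 (within the scatter).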

Compound 4, largest response reached (reported as percent of maximum), in percent of the reference or control that the assay uses: 76.9%
The estimate for compound 4 lay 6.1 percentage points above the measured number; measured number inside the range.
By their numbers in this assay, from the lowest: compounds 4, 1, 2 and 3 (each within the scatter of the next).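

Measured in this assay, isopropyl in place of methyl on a carbonyl carbon gives a number 6.2 percentage points lower from compound 2 to compound 4 (within the scatter) and isopropyl in place of propyl on that carbon gives a number 2.4 percentage points lower from compound 1 to compound 4 (within the scatter) as the second step. A branched chain on this carbonyl carbon therefore joins the straight propyl-bearing chain of compound 1 and the acetyl of compound 2, and no step among these three lies beyond the scatter. As far as these compounds go, whether a longer chain, a cyclopropyl ring or an amine on this carbon would give a step beyond the scatter stays open. Nothing available accounts for these numbers.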